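Compound 2 to compound 3: adding two methoxy groups

This account rests on a few compounds, and the source may have more. Where it says the series, first, only, none or still open, it means among the compounds named here.

In an ADME assay on HeLa cells (Homo sapiens) for cytotoxicity, read by crystal violet staining, with a stated time of 72 h (a higher number here means that more compound is tolerated, a lower number that less compound is tolerated), compound 1 (`COC(=O)c1cc(CCCOc2c(C)cc(-c3noc(C(F)(F)F)n3)cc2C)on1`) gives 35400 nM. Compound 2 (`Cc1cc(-c2noc(C(F)(F)F)n2)cc(C)c1OCCCc1cc(-c2ccccc2)no1`) gives > 100000 nM, which is a limit of the assay and not a number. This is the limit of > 100000 nM in this assay, at which 1 of the 2 values shown sits, so the true position of compound 2 is not known.

Compound 3 (`COc1ccc(-c2cc(CCCOc3c(C)cc(-c4noc(C(F)(F)F)n4)cc3C)on2)cc1OC`) carries 3,4-dimethoxyphenyl in place of phenyl on an aromatic carbon. Going by the values given here, one measured step bears on this place: an at least 2.8-fold higher number from compound 1 to compound 2 (0.45 log units; beyond the scatter), with phenyl in place of methoxycarbonyl on an aromatic carbon. It shows that a change at this carbon can move the number in this assay beyond the scatter. It does not cover any group on the phenyl itself, so it gives only a rough guide to size and none to direction.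

Only a small move toward a lower number is expected, and the result may well be a limit again. The expected step is an at least 1.1-fold lower number from compound 2 to compound 3 (0.04 log units; that floor lies within the scatter). For compound 3 the estimated value is 90000 nM, with an expected range of 35000 nM to 100000 nM.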

Compound 3, half-maximal cytotoxic concentration: 41900 nM
Beside the measured number, compound 3's estimate is 2.1-fold (0.33 log units) above it, within the range that was stated.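

In this assay the step from phenyl to 3,4-dimethoxyphenyl reads beyond the scatter (an at least 2.3-fold lower number from compound 2 to compound 3 (0.37 log units; beyond the scatter)), so groups on the phenyl itself register at this carbon, which the change from methoxycarbonyl to phenyl could not show. The new group also does not separate from methoxycarbonyl (a 1.2-fold higher number from compound 1 to compound 3 (0.07 log units; within the scatter)), so an aromatic ring at this carbon does not by itself place a compound at the limit of the assay, and compound 3 and compound 1 read as equal within the scatter. Compound 2 gives > 100000 nM, which is a limit of the assay and not a number, so the step to compound 3 gives only a floor for the true size of the change because its starting point is not known: the limit of > 100000 nM in this assay, at which 1 of the 3 values shown sits.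

The compounds shown do not separate the contributions of the two methoxy groups of 3,4-dimethoxyphenyl, so it stays open whether one of them alone would give the same result. Also open, from the compounds shown here alone, is how an amine or a carboxylic acid on the phenyl, or a longer chain in its place at this carbon, would read in this assay on the shared core.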